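The source may hold more compounds than are shown below. What is called first, only, known or untested is meant among the compounds shown, and "the series" means these compounds.

Measured in a functional assay on HepG2 cells (Mus musculus) for antiproliferative activity against HepG2 (Homo sapiens), read by MTT assay, with a stated time of 48 h; a lower number here means a stronger inhibitor, a higher number a weaker inhibitor:

Compound 1 `COc1cccc(C(=O)Nc2nnc(/C=C/c3cc(OC)c(OC)c(OC)c3Br)s2)c1`: 120 nM
Compound 2 `COc1ccc(C(=O)Nc2nnc(/C=C/c3cc(OC)c(OC)c(OC)c3Br)s2)cc1`: 220 nM
Compound 3 `COc1cc(/C=C/c2nnc(NC(=O)c3cccc(Cl)c3)s2)c(Br)c(OC)c1OC`: 150 nM

Compound 3, at 150 nM, sits among values that cannot be told apart. Its steps, a 1.3-fold higher number from compound 1 to compound 3 (0.10 log units; within the scatter) and a 1.5-fold lower number from compound 2 to compound 3 (0.17 log units; within the scatter), both lie within the scatter, so it holds no distinct rank in this small set.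

Compound 4 `COc1cc(/C=C/c2nnc(NC(=O)c3ccccc3)s2)c(Br)c(OC)c1OC` has hydrogen in place of chloro on an aromatic carbon. Among the measured compounds shown here, no measured step makes this exact change. The nearest evidence comes from changes to the same aryl group. Exchanging methoxy for chloro gave a 1.3-fold higher number from compound 1 to compound 3 (0.10 log units; within the scatter), and moving the methoxy gave a 1.8-fold higher number from compound 1 to compound 2 (0.26 log units; within the scatter). Both were within the scatter, as was a 1.5-fold lower number from compound 2 to compound 3 (0.17 log units; within the scatter). These three compounds therefore show little response to the aryl substituents tried so far, although none of them lacks a substituent on that ring, and that leaves the expectation less firm.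

No step beyond the scatter is expected, and the estimate is a 1.3-fold higher number from compound 3 to compound 4 (0.10 log units; within the scatter). Any drift towards a higher number would be slight and could not be told from noise.

The estimated value for compound 4 is 190 nM, with an expected range from 90 nM to 420 nM.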

Compound 4, half-maximal inhibitory concentration: 180 nM
For compound 4 the middle estimate is 1.1-fold (0.02 log units) above the measured one; low and high end bracket the measured number.
By their numbers in this assay, from the lowest: compounds 1, 3, 4 and 2 (each within the scatter of the next).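

Among the compounds shown here, compound 4 is the first compound here whose benzoyl ring carries only hydrogen, and in this assay hydrogen in place of chloro gave a 1.2-fold higher number from compound 3 to compound 4 (0.08 log units; within the scatter). Hydrogen in place of methoxy gave a 1.2-fold lower number from compound 2 to compound 4 (0.09 log units; within the scatter) and a 1.5-fold higher number from compound 1 to compound 4 (0.18 log units; within the scatter), so a chloro or methoxy group on this ring is not needed for a value in this range, and none of the three steps leaves the scatter. Nothing in the data shown accounts for this lack of response to the substituent.

These four compounds leave open whether this tolerance extends to groups unlike chloro and methoxy on the same ring, such as a carboxylic acid, a dimethylamino group or a longer chain such as butoxy, any of which could show a step beyond the scatter. They also leave open how the values respond to changes elsewhere in the molecule, for instance exchanging the bromine on the shared core for hydrogen or replacing the amide hydrogen with a methyl group, since all four compounds share those features.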